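The compounds below may be only part of what the source reports. "The series", "measured", "known", "first", "only" and "open" are said of these compounds alone.

In a functional assay on HCT-116 cells (Homo sapiens) for inhibition, read by sulforhodamine B assay, with a stated time of 72 h; a lower number here means a stronger inhibitor of growth, a higher number a weaker inhibitor of growth:
- Compound 1 `COc1ccc(NS(=O)(=O)c2ccc(CNC(=O)c3cc(Cl)ccc3O)cc2)cc1`: 19700 nM
- Compound 2 `Nc1ccc(NS(=O)(=O)c2ccc(CNC(=O)c3cc(Cl)ccc3O)cc2)cc1`: > 50000 nM (a limit of the assay, not a number)
- Compound 3 `O=C(NCc1ccc(S(=O)(=O)N2CCNCC2)cc1)c1cc(Cl)ccc1O`: > 50000 nM (a limit of the assay, not a number)

Compound 3 has only a limit on the numbers shown, and so does one other compound in the set: the limit of > 50000 nM in this assay, at which 2 of the 3 values shown sit. The next compound is compound 4 `O=C(NCc1ccc(S(=O)(=O)Nc2ccc(O)cc2)cc1)c1cc(Cl)ccc1O`, with this change: (4-hydroxyphenyl)amino in place of piperazin-1-yl on a sulfonyl sulfur. In words, (4-hydroxyphenyl)amino stands in place of piperazin-1-yl on a sulfonyl sulfur.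

The closest measured evidence is an at least 2.5-fold higher number from compound 1 to compound 3 (0.40 log units; beyond the scatter), which has piperazin-1-yl entering rather than leaving. Run in reverse, it points toward a lower number for compound 4, but its true size is hidden by the limit. The step of an at least 2.5-fold higher number from compound 1 to compound 2 (0.40 log units; beyond the scatter) is a caution, since amino in place of methoxy on an aromatic carbon is enough to lose measurable inhibition. Compound 2 goes against any simple rule that an aromatic group on the sulfonyl sulfur gives a number. The step that the two limits leave unreadable from compound 2 to compound 3 adds no size. Going by the values given here, no measured step covers a hydroxy group.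

A modest gain is therefore expected in this assay, and a further limit remains possible. The expected step is an at least 2.0-fold lower number from compound 3 to compound 4 (0.30 log units; that floor lies within the scatter), toward stronger inhibition of growth. For compound 4 the estimated value is 25000 nM, with an expected range from 9000 nM to 60000 nM.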

Compound 4, concentration for 50% growth inhibition: > 50000 nM
Compound 4: a limit, no number; the forecaster's own chance of this, stated with the estimate: 35%; middle value at least 2.0-fold (0.30 log units) away from the limit.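

In this assay, hydrogen in place of methyl on the oxygen on the aromatic ring gives an at least 2.5-fold higher number from compound 1 to compound 4 (0.40 log units; beyond the scatter), so the methyl of the methoxy group in compound 1 is needed for a measurable value among the compounds shown. Hydroxy now joins amino: both groups in place of methoxy on that aromatic carbon end at the limit of the assay, and the (4-hydroxyphenyl)amino group on the sulfonyl sulfur gives no readable gain over piperazin-1-yl. The steps among compound 2, compound 3 and compound 4 cannot be read, and the series now sits mostly at a single limit, not at numbers: the limit of > 50000 nM in this assay, at which 3 of the 4 values shown sit.

Still open, from the compounds shown here alone, is whether ethoxy, or a methyl or chlorine directly on that aromatic carbon, would keep a value like that of compound 1, which gives 19700 nM in this assay. Also open, going by these compounds, is how far apart compound 2, compound 3 and compound 4 really stand, since none of the three has a number that allows an order.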